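Chalcone-linked pyrazoles: swapping the aryl group on the carbonyl

A few compounds are considered here, and "the series" means these few. Any claim that something is new, unique, unknown or untested is made for them only; others in the source may bear on it.

Measured compounds:
compound 1 `COc1cc(-c2cc(/C=C/C(=O)c3ccc(N)cc3)[nH]n2)cc(OC)c1OC`, -99%
compound 2 `COc1ccc(C(=O)/C=C/c2cc(-c3cc(OC)c(OC)c(OC)c3)n[nH]2)cc1OC`, -96%

In a functional assay on SF-539 cells (Homo sapiens) for cytotoxicity, read by sulforhodamine B assay, with a stated time of 48 h, tested at 100 uM (a lower number here means a stronger effect, a higher number a weaker effect of the compound at the concentration tested), compound 1 gives -99% and compound 2 gives -96%. Compound 2 carries the higher of the two numbers, yet the step of a number 3 percentage points higher from compound 1 to compound 2 (within the scatter) is within the scatter, so the two compounds cannot be told apart on this read-out. Compound 3 `COc1cc(-c2cc(/C=C/C(=O)c3ccc(F)c(F)c3)[nH]n2)cc(OC)c1OC` is not yet measured. It departs from compound 2 in one place: 3,4-difluorophenyl in place of 3,4-dimethoxyphenyl on a carbonyl carbon. Among the compounds with values here, the only step available, a number 3 percentage points higher from compound 1 to compound 2 (within the scatter), also exchanged the aryl group on the carbonyl carbon and left the number essentially unchanged, so the account rests on a single comparison. On that basis compound 3 is expected to show no step beyond the scatter, a number 4 percentage points higher from compound 2 to compound 3 (within the scatter). The estimate for compound 3 in this assay is therefore -92%, with a range from -100% to -65%.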

Compound 3, a percentage reported as activity, at one concentration (the size of the read-out at that concentration, not a potency): -63%
Beside the measured number, compound 3's estimate is 29 percentage points below it, outside the stated range (above it).
By their numbers in this assay, from the lowest: compounds 1 and 2 (each within the scatter of the next); then compound 3.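

In this assay, the aryl group on the carbonyl carbon proves not to be freely exchangeable: 3,4-difluorophenyl in place of 3,4-dimethoxyphenyl gives a number 33 percentage points higher from compound 2 to compound 3 (beyond the scatter), and 3,4-difluorophenyl in place of 4-aminophenyl gives a number 36 percentage points higher from compound 1 to compound 3 (beyond the scatter). Within the data shown here, the earlier pair showed only two aryl groups that could not be told apart, whereas these steps show that this position can move the read-out, with 3,4-difluorophenyl giving a weaker effect at the concentration tested than either of them. Nothing measured here accounts for that difference.

The three compounds leave open whether the weaker effect goes with the fluorine atoms themselves or with the absence of the methoxy or amino groups. They also leave open how a phenyl carrying a single fluorine, a nitrile or a carboxylic acid would read at this position.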